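The source may report more compounds than this note shows. Statements on the series, on what has been measured and on what is new or still open speak of the compounds shown alone.

Compound 3 `Cc1nc(C(=O)N2CCc3nc(C#Cc4ccccc4)sc3C2)cs1` is one of three compounds that share a core and differ only in the group on the carbonyl carbon. In an assay on HEK293 cells for negative allosteric modulation of metabotropic glutamate receptor 5 (Homo sapiens), read by FLIPR, with a stated time of 1 h (on this read-out higher numbers stand for weaker inhibition and lower numbers for stronger inhibition), compound 1 `CC(=O)N1CCc2nc(C#Cc3ccccc3)sc2C1` gives 90 nM. For compound 2 `O=C(C1CCC(F)(F)CC1)N1CCc2nc(C#Cc3ccccc3)sc2C1` this assay reports only a limit, > 10000 nM. For compound 3 this assay likewise reports only a limit, > 10000 nM, so compound 3 stands at the limit, together with compound 2 (the limit of > 10000 nM in this assay, at which 2 of the 3 values shown sit). The step of an at least 110-fold higher number from compound 1 to compound 2 (2.04 log units; beyond the scatter) and the step of an at least 110-fold higher number from compound 1 to compound 3 (2.04 log units; beyond the scatter) were both large. The step that the two limits leave unreadable from compound 2 to compound 3 cannot be read.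

Compound 4 `O=C(N1CCCC1)N1CCc2nc(C#Cc3ccccc3)sc2C1` differs from compound 3 by pyrrolidin-1-yl in place of 2-methyl-1,3-thiazol-4-yl on a carbonyl carbon. The two readable steps both went from methyl to a larger group and both lost strongly; pyrrolidin-1-yl is again larger than methyl, but with fewer heavy atoms than either group that entered there. Compound 4 is therefore expected to sit between compound 1 and the limit, with a step of an at least 3.3-fold lower number from compound 3 to compound 4 (0.52 log units; beyond the scatter) that is estimated rather than measured. Compound 4 is estimated at 3000 nM, in a range from 300 nM to 10000 nM.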

Compound 4, half-maximal inhibitory concentration: > 10000 nM
Compound 4: a limit, no number (the forecaster's own chance of this, stated with the estimate: 40%); middle value at least 3.3-fold (0.52 log units) away from the limit.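

In this assay compound 4 gives > 10000 nM as a limit and not a number, and the steps among compound 2, compound 3 and compound 4 cannot be read, so no order among these three groups can be given. Pyrrolidin-1-yl on this carbonyl carbon still brings an at least 110-fold higher number from compound 1 to compound 4 (2.04 log units; beyond the scatter) and so shows that the large loss does not depend on an aromatic ring, on fluorine or on hydrogen-bond acceptors in the group that enters. Of the groups shown here, only the methyl of compound 1 leaves a readable value: the limit of > 10000 nM in this assay, at which 3 of the 4 values shown sit.

As far as these compounds go, how far the group can grow beyond methyl remains open. Ethyl, cyclopropyl, methoxy or dimethylamino on the same carbonyl carbon would show whether any group other than methyl gives a readable value.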